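The compounds below may be only part of what the source reports. "The series", "measured", "known", "first", "only" and "open" are said of these compounds alone.

Measured so far:

Compound 1, `O=C(O)c1cc(F)c(F)c(F)c1O`: 66%
Compound 2, `COC(=O)c1c(O)c(F)c(F)c(F)c1F`: 90%

In a toxicity assay on the whole organism (strain CD-1) for cytotoxicity, with Mus musculus as the target, with a stated time of 14 days, at a dose of 150 mg/kg by the intraperitoneal route (a lower number here means a stronger effect, a higher number a weaker effect of the compound at the dose given), compound 1 gives 66%, and in this assay compound 2 gives 90%. Of the two numbers, compound 2 stands highest; the nearest is compound 1, whose number is lower by a gap beyond the scatter. Among the measured compounds shown here, the two compounds differ in more than one place, so their values show only that compound 2 is the weaker of the pair in this assay.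

Compound 3, `COC(=O)c1cc(F)c(F)c(F)c1O`, has not yet been measured in this assay. It differs from compound 2 by hydrogen in place of fluoro on an aromatic carbon. No measured step of this kind is available among these compounds, so the expectation rests on where compound 2 stands. A hydrogen in place of fluoro is a small change, and compound 3 is expected to stay near compound 2, with a step of a number 10 percentage points lower from compound 2 to compound 3 (within the scatter) that is expected to be downward, but of a size close to the scatter rather than clearly beyond it. Compound 3 is therefore estimated at 80% in this assay, within a range from 60% to 98%.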

Compound 3, a percentage reported as activity, at one dose (the size of the read-out at that dose, not a potency): 100%
For compound 3 the middle estimate is 20 percentage points below the measured one; measured number above the stated range.
By their numbers in this assay, from the lowest: compound 1; then compounds 2 and 3 (each within the scatter of the next).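

At the aromatic carbon ortho to the methoxycarbonyl group, hydrogen in place of fluoro gives a number 10 percentage points higher from compound 2 to compound 3 (within the scatter) in this assay and so separates the two compounds by no more than the usual scatter, which means that in this pair the fluoro group at this position makes no readable difference at the dose given. Among the compounds shown here, the same hydrogen-bearing ring also provides the first comparison that isolates the carboxylic acid from its methyl ester: with methyl in place of hydrogen on that oxygen, the read-out shows a number 34 percentage points higher from compound 1 to compound 3 (beyond the scatter) in this assay and compound 3 is the weaker of this pair, a contrast that compounds 1 and 2 could not show, since they differ in more than one place. Nothing given here accounts for either result.

The compounds shown leave open whether a chloro group or an amine on this aromatic carbon would stay as close to compound 3 as fluoro does. They also leave open how an ethyl ester, a longer chain on the ester oxygen, or an amide in place of the ester would read in this assay.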